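This account rests on a few compounds, and the source may have more. Where it says the series, first, only, none or still open, it means among the compounds named here.

Among the measured compounds shown here, compound 1 `CCCCCCCCOC(=O)N[C@H]1CNC1=O` sets the mark in an assay on HEK293 cells for inhibition of N-acylethanolamine-hydrolyzing acid amidase (Homo sapiens), read by fluorescence, with stated times of 10 min and 50 min (a lower number here means a stronger inhibitor, a higher number a weaker inhibitor), where compound 1 gives 37 nM, the lowest of the three numbers so far. Compound 3 `O=C(N[C@H]1CNC1=O)OCCCCCC1CCCCC1` sits close by: in this assay compound 3 gives 49 nM, and the step of a 1.3-fold higher number from compound 1 to compound 3 (0.12 log units; within the scatter) is within the scatter. Compound 2 `O=C(N[C@H]1CNC1=O)OCCCCCc1ccccc1` lies furthest off, giving 298 nM in this assay, a step of an 8.1-fold higher number from compound 1 to compound 2 (0.91 log units; beyond the scatter). The unmeasured compound 4 `O=C(N[C@H]1CNC1=O)OCCCCc1ccccc1` differs from compound 1 as phenyl in place of butyl on a saturated chain carbon, four bonds along the chain from an oxygen next to a carbonyl group. For the measured compounds named here, the measured step that bears most directly on this change is the one from compound 1 to compound 2, where a phenyl likewise took the chain end, though five bonds along rather than four; that step was an 8.1-fold higher number from compound 1 to compound 2 (0.91 log units; beyond the scatter). The step of a 6.1-fold lower number from compound 2 to compound 3 (0.78 log units; beyond the scatter) points the same way, the phenyl-bearing compound 2 giving the highest number of the three. A step of similar direction and size is therefore expected; the step expected in this assay is a 9.5-fold higher number from compound 1 to compound 4 (0.98 log units; beyond the scatter). Compound 4 is estimated at 350 nM, with a range from 120 nM to 1000 nM.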

Compound 4, half-maximal inhibitory concentration: 1110 nM
Estimate against measurement, compound 4: 3.2-fold (0.50 log units) below; the whole stated range lies below it.
By their numbers in this assay, from the lowest: compounds 1 and 3 (each within the scatter of the next); then compound 2; then compound 4.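

Among the compounds shown here, with phenyl in place of butyl, four bonds along the chain from an oxygen next to a carbonyl group, the change gives a 30-fold higher number from compound 1 to compound 4 (1.48 log units; beyond the scatter) as the largest step so far in this assay. Phenyl at this place is thus less well tolerated than at five bonds along: compound 4 gives 1110 nM against compound 2 at 298 nM in the same assay, so the distance of the ring along the chain matters as well as its presence. No measurement in hand accounts for this dependence on chain distance.

On these data alone, whether cyclohexyl at four bonds along would stay close to compound 3 or fall away as phenyl does remains open. Also open, as far as these compounds go, is how a longer chain ending in phenyl, or an amine or a carboxylic acid at the chain end, would read here.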